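Adding Chlorine to the Phenyl Ring: an Expected Value

This account rests on a few compounds, and the source may have more. Where it says the series, first, only, none or still open, it means among the compounds named here.

Compound 1, `COc1cc(/C=C/C(=O)c2cccc(-n3cc(-c4ccc(Cl)cc4)[nH]c3=O)c2)cc(OC)c1OC`: in a functional assay on SF-295 cells (Homo sapiens) for inhibition (on this read-out lower numbers stand for stronger inhibition of growth and higher numbers for weaker inhibition of growth), compound 1 gives 24300 nM.
Compound 2, `COc1cc(/C=C/C(=O)c2cccc(-n3cc(-c4ccccc4)[nH]c3=O)c2)ccc1O`: in this assay compound 2 gives 3040 nM.
Compound 3, `O=C(/C=C/c1cccc(O)c1)c1cccc(-n2cc(-c3ccccc3)[nH]c2=O)c1`: in this assay compound 3 gives 18200 nM.

Among these three numbers compound 3 stands second highest, close to compound 1 and well apart from compound 2. Going by the values given here, the one step between compounds that differ in a single place, a 6.0-fold higher number from compound 2 to compound 3 (0.78 log units; beyond the scatter), concerns the hydroxyphenyl end of the chain and says nothing about the other aromatic ring.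

Compound 4, `O=C(/C=C/c1cccc(O)c1)c1cccc(-n2cc(-c3ccc(Cl)cc3)[nH]c2=O)c1`, differs from compound 3 by chloro in place of hydrogen on an aromatic carbon. Among the compounds with values here, no measured step isolates this change. Within the data shown here, compound 1 and compound 2 differ in two places at once, so their values show only that in this assay compound 1 gives 24300 nM while compound 2 gives 3040 nM, without separating the chloro from the methoxy pattern. Among the measured compounds shown here, with no step bearing directly on the change, the expectation is a number close to that of compound 3, with no step beyond the scatter. Compound 4 is therefore estimated at 20000 nM, within 8000 nM to 50000 nM. The expected step is a 1.1-fold higher number from compound 3 to compound 4 (0.04 log units; within the scatter).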

Compound 4, concentration for 50% growth inhibition: 1790 nM
Compound 4: the middle estimate sits 11-fold (1.05 log units) above what was measured; the whole stated range lies above it.
By their numbers in this assay, from the lowest: compounds 4 and 2 (each within the scatter of the next); then compounds 3 and 1 (each within the scatter of the next).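

The change from phenyl to 4-chlorophenyl gives a 10-fold lower number from compound 3 to compound 4 (1.01 log units; beyond the scatter) in this assay, and this single chlorine atom is the only difference between the two structures. Going by these compounds alone, the earlier step touched only the hydroxyphenyl end of the chain, so this is the first reading of what a change on the other aromatic ring can do, and here it is large. Nothing available gives a cause for a step of this size.

On these data alone, it remains open whether fluoro, bromo or methoxy in the same place would bring a step of similar size. Chloro does not go with a low number in every compound, since compound 1 also carries it and gives 24300 nM in this assay, so whether the gain depends on the group at the far end of the chain also stays unsettled.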